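The compounds below may be only part of what the source reports. "The series", "measured", "known", "first", "only" and "open" are said of these compounds alone.

Among the compounds with values here, in a functional assay on DU-145 cells (Homo sapiens) for inhibition, read by trypan blue exclusion, with a stated time of 96 h (on this read-out higher numbers stand for weaker inhibition of growth and lower numbers for stronger inhibition of growth), compound 1 `O=C(/C(=C\c1ccc(Cl)cc1Cl)S(=O)(=O)c1ccc(Br)cc1)c1ccc(Cl)cc1` gives 50000 nM as the only actual number available. Compound 2 `Cc1ccc(S(=O)(=O)/C(=C/c2c(O)cc(O)cc2O)C(=O)c2ccc(Br)cc2)cc1` is recorded at > 100000 nM and this is a limit of the assay, not a number. Compound 1 therefore has no second number to be ranked against.

Compound 3 `COc1ccccc1/C=C(\C(=O)c1ccc(Cl)cc1)S(=O)(=O)c1ccc(Br)cc1` keeps the core of compound 1 and differs from it in one place. The change 2-methoxyphenyl in place of 2,4-dichlorophenyl on a double-bonded chain carbon bound to a double-bonded chain carbon puts 2-methoxyphenyl in place of 2,4-dichlorophenyl on a double-bonded chain carbon bound to a double-bonded chain carbon.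

Within the data shown here, no pair of measured compounds shows what a change at this place does in this assay and no step of any size is available as a guide. The expectation is for no step beyond the usual scatter in either direction, starting from compound 1 at 50000 nM. There is some chance that compound 3 also ends as a limit. The estimated move is a 1.1-fold lower number from compound 1 to compound 3 (0.05 log units; within the scatter) and remains only an expectation. For compound 3 the expected value is 45000 nM within an estimated range of 15000 nM to 100000 nM until the measurement is in.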

Compound 3, concentration for 50% growth inhibition: 10000 nM
The estimate for compound 3 lay 4.5-fold (0.65 log units) above the measured number; the whole stated range lies above it.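

In this assay, within the data shown here, putting 2-methoxyphenyl in place of 2,4-dichlorophenyl gives a 5.0-fold lower number from compound 1 to compound 3 (0.70 log units; beyond the scatter), the first step that can be read at this place. It shows that the group on a double-bonded chain carbon bound to a double-bonded chain carbon is not a silent part of the structure, since changing it alone, with the rest of the core of compound 1 kept, moves the concentration for growth inhibition beyond the scatter. As a single pair, however, it cannot separate the loss of the two chlorine atoms from the arrival of the methoxy group, and it gives no reason for the step.

Among these compounds, compound 2 stands only as a limit of the assay, not as a number, and adds no second step: the limit of > 100000 nM in this assay, at which 1 of the 3 values shown sits. Whether a plain phenyl, or a phenyl carrying an amine or a carboxylic acid, at this same place would lower the number further or raise it again stays open, as does whether the step seen here would hold with other groups elsewhere on the core.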